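This account rests on a few compounds, and the source may have more. Where it says the series, first, only, none or still open, it means among the compounds named here.

Measured compounds:
- compound 1, `Cc1ccc(S(=O)(=O)N(C)CC(C)C)cc1C#Cc1cc(Cl)ccc1OCC(=O)O`: 4.2 nM
- compound 2, `O=C(O)COc1ccc(Cl)cc1C#Cc1ccccc1Cl`: 28 nM
- compound 3, `CCCS(=O)(=O)c1ccc(C)c(C#Cc2cc(Cl)ccc2OC(CC)C(=O)O)c1`: 30 nM

All three were run in an assay on CHO cells for displacement of a labelled ligand from prostaglandin D2 receptor 2 (Homo sapiens), read by scintillation counting; on this read-out higher numbers stand for weaker inhibition and lower numbers for stronger inhibition. Compound 1 gives the lowest number of the three, and its gaps to compound 2 and to compound 3 both lie beyond the scatter, so compound 1 is the strongest inhibitor in this assay among those measured.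

Compound 4, `CCN(CC)S(=O)(=O)c1ccc(C)c(C#Cc2cc(Cl)ccc2OCC(=O)O)c1`, has not yet been measured. It differs from compound 1 in one place:
diethylamino in place of isobutyl(methyl)amino on a sulfonyl sulfur
The sulfonyl sulfur keeps its aromatic carbon neighbour; only the amino substituent on it changes, isobutyl(methyl)sulfamoyl becoming diethylsulfamoyl. Among the measured compounds shown here, no measured pair shows the same change, so the expectation rests on compound 1 alone, at 4.2 nM, and on the small size of the change. A step of a 1.4-fold higher number from compound 1 to compound 4 (0.15 log units; within the scatter) is expected, with the number staying close to that of compound 1, most likely within the scatter or slightly weaker. For compound 4 in this assay the estimate is 6 nM, in the range 2.5 nM to 15 nM.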

Compound 4, inhibition constant: 3.4 nM
Estimate against measurement, compound 4: 1.8-fold (0.25 log units) above, and the stated range covers the measured number.
By their numbers in this assay, from the lowest: compounds 4 and 1 (each within the scatter of the next); then compounds 2 and 3 (each within the scatter of the next).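

Among the compounds shown here, on the sulfonyl sulfur, diethylamino in place of isobutyl(methyl)amino gives a 1.2-fold lower number from compound 1 to compound 4 (0.09 log units; within the scatter) in this assay, the first step that isolates this position. The two amino substituents, which differ in shape and by one heavy atom, give numbers that cannot be told apart, so this position accepts at least this change. No measurement at hand explains the result.

Still open, going by these compounds, is whether a ring amine such as piperidine or morpholine on the sulfonyl sulfur, or a longer chain such as dipropylamino, stays in this range.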